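The compounds below may be only part of what the source reports. "The series", "measured", "known", "first", "only" and "open" are said of these compounds alone.

Measured in a functional assay on IMR-32 cells (Homo sapiens) for cytotoxicity, read by sulforhodamine B assay, with a stated time of 48 h; a higher number here means a weaker inhibitor, a lower number a stronger inhibitor:
compound 1 `O=C(c1cccnc1)c1ccccc1O` gives 33700 nM
compound 2 `O=C(c1cccnc1)c1cccc(Cl)c1O` gives 26000 nM
compound 3 `C=CCOc1ccc(Br)cc1C(=O)c1cccnc1` gives 88000 nM

Compound 1 stands in the middle of these three numbers, within the scatter of compound 2 and under compound 3. The change to compound 4 `Cc1ccc(O)c(C(=O)c2cccnc2)c1` is methyl in place of hydrogen on an aromatic carbon and amounts to methyl in place of hydrogen on an aromatic carbon, para to a hydroxy group. Among the compounds with values here, the one measured step of this kind is a 1.3-fold lower number from compound 1 to compound 2 (0.11 log units; within the scatter) for chloro in place of hydrogen on an aromatic carbon, and it stayed within the scatter. No step beyond the scatter is therefore expected in this assay in either direction. The expected outcome is a 1.1-fold lower number from compound 1 to compound 4 (0.05 log units; within the scatter) and this estimate stays within the scatter. Compound 4 is expected at 30000 nM with 15000 nM to 60000 nM as its estimated range.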

Compound 4, half-maximal inhibitory concentration: 5540 nM
The estimate for compound 4 lay 5.4-fold (0.73 log units) above the measured number; the whole stated range lies above it.
By their numbers in this assay, from the lowest: compound 4; then compounds 2 and 1 (each within the scatter of the next); then compound 3.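

In this assay, methyl in place of hydrogen on an aromatic carbon, para to a hydroxy group, gives a 6.1-fold lower number from compound 1 to compound 4 (0.78 log units; beyond the scatter). The only other single-place step, a 1.3-fold lower number from compound 1 to compound 2 (0.11 log units; within the scatter), stayed within the scatter, so this is the one change shown on the shared core that moves the number beyond it. Nothing available accounts for the size of this step.

Going by these compounds, whether an ethyl or methoxy group at this position would behave like methyl remains open. So does whether the step depends on the hydroxy group, which an amine in its place would test.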